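The source may report more compounds than this note shows. Statements on the series, on what has been measured and on what is new or still open speak of the compounds shown alone.

Working notes on the series in a functional assay on A549 cells (Homo sapiens) for antiproliferative activity, with a stated time of 72 h; on this read-out higher numbers stand for weaker inhibition and lower numbers for stronger inhibition.

Compound 1 `COc1ccc(C2CC(c3ccccc3)=NN2c2nc(-c3ccc(Cl)cc3)c(C#N)c(=O)n2C)cc1` gives 23800 nM in this assay. Among the compounds with values here, compound 2 `COc1ccc(C2CC(c3ccc(Cl)cc3)=NN2c2nc(-c3ccc(Cl)cc3)c(C#N)c(=O)n2C)cc1` gives 35700 nM in this assay, the highest of the two numbers so far; the nearest is compound 1, and the step of a 1.5-fold higher number from compound 1 to compound 2 (0.18 log units; within the scatter) stays within the scatter. Compound 3 `COc1ccc(C2=NN(c3nc(-c4ccc(Cl)cc4)c(C#N)c(=O)n3C)C(c3ccc(OC)cc3)C2)cc1` is not yet measured. The change from compound 2 to compound 3 is methoxy in place of chloro on an aromatic carbon. Within the data shown here, the one step that bears on it, a 1.5-fold higher number from compound 1 to compound 2 (0.18 log units; within the scatter), exchanges hydrogen for chloro at the same place and stays within the scatter, so a substituent at that place has so far not moved the number. Among the measured compounds shown here, the methoxy is not represented anywhere else, so no further step bears on it. On this basis the expected step of a 1.3-fold lower number from compound 2 to compound 3 (0.11 log units; within the scatter) is none beyond the scatter. For compound 3 the estimate in this assay is 28000 nM, with a range from 11000 nM to 70000 nM.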

Compound 3, half-maximal inhibitory concentration: 39700 nM
For compound 3 the middle estimate is 1.4-fold (0.15 log units) below the measured one, and the stated range covers the measured number.
By their numbers in this assay, from the lowest: compounds 1, 2 and 3 (each within the scatter of the next).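

In this assay the exchange of chloro for methoxy, read as 4-chlorophenyl to 4-methoxyphenyl, brings a hydrogen-bond acceptor to this aromatic carbon and gives a 1.1-fold higher number from compound 2 to compound 3 (0.05 log units; within the scatter). Methoxy in place of hydrogen at the same place gives a 1.7-fold higher number from compound 1 to compound 3 (0.22 log units; within the scatter), so compound 1, compound 2 and compound 3 all lie within the scatter of one another, and a second substituent, one larger than chloro by heavy-atom count, has not moved the number. No evidence on hand bears on this result.

As far as these compounds go, whether an amine or a carboxylic acid at this place would move the number beyond the scatter stays open. The rest of the shared core is the same in all three compounds, so changes elsewhere remain unread.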